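Changing the Amide Side Chain

A few compounds are considered here, and "the series" means these few. Any claim that something is new, unique, unknown or untested is made for them only; others in the source may bear on it.

In a functional assay on A549 cells (Homo sapiens) for antiproliferative activity, read by MTT assay, with a stated time of 72 h (a lower number here means a stronger inhibitor, a higher number a weaker inhibitor), compound 1 (`CC/C=C/C(=O)Nc1cccc(Oc2nc(Nc3ccc(OC)nc3)nc3c2CSCC3)c1`) gives 13100 nM and compound 2 (`CCC/C=C/C(=O)Nc1cccc(Oc2nc(Nc3ccc(OC)nc3)nc3c2CSCC3)c1`) gives 10800 nM. These two numbers sit within the usual scatter of each other, so compound 2 stands level with compound 1. Compound 3 (`COc1ccc(Nc2nc3c(c(Oc4cccc(NC(=O)C=C(C)C)c4)n2)CSCC3)cn1`) alters one group of compound 2: 2-methylprop-1-en-1-yl in place of pent-1-en-1-yl on a carbonyl carbon, (2-methylprop-1-en-1-yl in place of pent-1-en-1-yl on a carbonyl carbon). Among the compounds with values here, only one measured step bears on this, and it concerns the same chain: a 1.2-fold lower number from compound 1 to compound 2 (0.08 log units; within the scatter). Within the data shown here, that step is small, but it is a thin guide, as no compound with the 2-methylprop-1-en-1-yl group has been measured yet. No change beyond the scatter is therefore expected in this assay. The estimated change is a 1.1-fold higher number from compound 2 to compound 3 (0.05 log units; within the scatter). For compound 3 the expected value is 12000 nM, with an estimated range from 5000 nM to 30000 nM.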

Compound 3, half-maximal inhibitory concentration: 16800 nM
For compound 3 the middle estimate is 1.4-fold (0.15 log units) below the measured one; measured number inside the range.
By their numbers in this assay, from the lowest: compounds 2, 1 and 3 (each within the scatter of the next).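

In this assay, within the data shown here, the 2-methylprop-1-en-1-yl group on the carbonyl carbon brings a branched chain to a place that had so far held only unbranched ones, and the result stays within the scatter of both earlier compounds (a 1.6-fold higher number from compound 2 to compound 3 (0.19 log units; within the scatter); a 1.3-fold higher number from compound 1 to compound 3 (0.11 log units; within the scatter)). Compound 3 has one heavy atom fewer than compound 2 and keeps the one double bond outside aromatic rings, so these three compounds show that neither this branching nor this change in size moves the number beyond the scatter. No supporting data are available to account for the small differences seen here.

Still open, going by these compounds, is whether any group on this carbonyl carbon can shift the number beyond the scatter. A chain ending in a dimethylamino group or a carboxylic acid would test this with a very different group.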